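A few compounds are considered here, and "the series" means these few. Any claim that something is new, unique, unknown or untested is made for them only; others in the source may bear on it.

Measured compounds:
- compound 1, `CC(C)(C)Cc1cnc(CCc2ccc(-c3ccccc3C(=O)O)cc2)[nH]1`, gives 6.3 nM in an in vitro functional assay on cells for agonist activity at Bombesin receptor subtype-3 (Mus musculus), read by luminescence and calcium flux; on this read-out lower numbers stand for an effect already at smaller amounts and higher numbers for an effect only at larger amounts of compound
- compound 2, `CCCCc1cnc(Cc2ccc(-c3ccccc3C(=O)O)cc2)[nH]1`, gives only a limit of the assay, > 10000 nM, in this assay
- compound 3, `CCCCc1cnc(/C=C/c2ccc(-c3ccccc3C(=O)O)cc2)[nH]1`, gives 10000 nM in this assay

Compound 1 stands lowest among the two numbers shown, with compound 3 the nearest and its number far higher, well beyond the usual scatter. Compound 2 sits at a limit of the assay, as the evidence records: the limit of > 10000 nM in this assay, at which 1 of the 3 values shown sits. Both compounds 2 and 3 differ from compound 1 in more than one place, so no single step is shown between measured compounds.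

The unmeasured compound 4, `O=C(O)c1ccccc1-c1ccc(CCc2ncc(Cc3ccccc3)[nH]2)cc1`, keeps the chain and core of compound 1 and changes one group: phenyl in place of tert-butyl on a saturated chain carbon bound to an aromatic carbon. With no measured step of this kind in hand, the size of the change in this assay rests on expectation alone. A modest loss is expected, as the step of a 6.3-fold higher number from compound 1 to compound 4 (0.80 log units; beyond the scatter) is taken to lie somewhat beyond the scatter. Compound 4 is therefore estimated at 40 nM, with a range from 5 nM to 400 nM.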

Compound 4, half-maximal effective concentration: 11 nM
Beside the measured number, compound 4's estimate is 3.6-fold (0.56 log units) above it, within the range that was stated.
By their numbers in this assay, from the lowest: compounds 1 and 4 (each within the scatter of the next); then compound 3.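

In this assay, the swap of tert-butyl for phenyl on a saturated chain carbon bound to an aromatic carbon gives a 1.7-fold higher number from compound 1 to compound 4 (0.24 log units; within the scatter), so the two groups cannot be told apart on this read-out. Going by these compounds alone, this is the first single step measured at this place, and it shows that a six-membered aromatic ring of carbon only serves there as well as the branched group with no ring, at a cost of two more heavy atoms. Nothing in the data shown gives a reason for this agreement.

As far as these compounds go, whether a cyclohexyl group, or a phenyl carrying an amine, would hold the number at this place remains open. So does the outcome for a longer chain in place of neopentyl or benzyl, since compound 2 and compound 3 each differ from compound 1 in more than one place.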